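Removing Chloro and Trifluoromethyl from the Benzamide Ring

This account rests on a few compounds, and the source may have more. Where it says the series, first, only, none or still open, it means among the compounds named here.

Measured compounds:
Compound 1 `COc1cc(-c2nn(-c3cccc(NC(=O)c4cccc(C(F)(F)F)c4)c3)cc2-c2ccncc2)ccc1Cl` gives 2300 nM in a functional assay on SF-539 cells (Homo sapiens) for inhibition, read by sulforhodamine B assay, with a stated time of 48 h; a higher number here means a weaker inhibitor of growth, a lower number a stronger inhibitor of growth.
Compound 2 `COc1cc(-c2nn(-c3cccc(NC(=O)c4ccc(Cl)c(C(F)(F)F)c4)c3)cc2-c2ccncc2)ccc1Cl` gives 20300 nM in this assay.
Compound 3 `O=C(Nc1cccc(-n2cc(-c3ccncc3)c(-c3ccc(Cl)c(O)c3)n2)c1)Nc1cc(C(F)(F)F)cc(C(F)(F)F)c1` gives 1490 nM in this assay.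

Compound 2 stands at the highest of the three numbers in this assay; compound 1 sits nearest to it and compound 3 furthest, both with lower numbers beyond the scatter. The step to the unmeasured compound 4 `COc1cc(-c2nn(-c3cccc(NC(=O)c4ccccc4)c3)cc2-c2ccncc2)ccc1Cl` is phenyl in place of 4-chloro-3-(trifluoromethyl)phenyl on a carbonyl carbon: the benzamide ring loses both its chloro and its trifluoromethyl substituents at once.

Going by the values given here, only one measured step bears directly on this change. Going from compound 1 to compound 2 added a chloro group to the ring and gave an 8.8-fold higher number from compound 1 to compound 2 (0.95 log units; beyond the scatter). Taking that chloro away again should undo that rise, and compound 4 additionally lacks the trifluoromethyl that compound 1 carries, for which no comparison exists among the measured compounds. The expectation is therefore a clear fall in the number, back toward the value of compound 1, with added uncertainty about where the bare phenyl lands. This corresponds to an expected 6.8-fold lower number from compound 2 to compound 4 (0.83 log units; beyond the scatter). Compound 4 is estimated to give 3000 nM in this assay, within a range from 1000 nM to 12000 nM.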

Compound 4, concentration for total growth inhibition: 2880 nM
Beside the measured number, compound 4's estimate is 1.0-fold (0.02 log units) above it, within the range that was stated.
By their numbers in this assay, from the lowest: compounds 3, 1 and 4 (each within the scatter of the next); then compound 2.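

Compound 4 shows that the benzamide ring does not need either substituent to hold its number in this assay: stripping both gives a 7.0-fold lower number from compound 2 to compound 4 (0.85 log units; beyond the scatter). Going by these compounds alone, it also supplies the comparison for the trifluoromethyl group that the earlier compounds lacked, since hydrogen in its place gives a 1.3-fold higher number from compound 1 to compound 4 (0.10 log units; within the scatter), so that group's removal from the ring makes no readable difference here. Among these three amides, only compound 2, the one carrying the chloro, stands apart, and nothing shown here explains why that substituent goes with the weaker growth inhibition.

The compounds shown leave open whether a chloro on the benzamide ring without the trifluoromethyl would give the same rise as an 8.8-fold higher number from compound 1 to compound 2 (0.95 log units; beyond the scatter), and whether an amine or a carboxylic acid at that place would move the number at all. Within the data shown here, compound 3 differs from these amides in more than one place, so no step to it can be read.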